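A few compounds are considered here, and "the series" means these few. Any claim that something is new, unique, unknown or untested is made for them only; others in the source may bear on it.

Compound 2, `COc1ccc(-c2nc(/C=C/c3cc4ccccc4nc3OC)no2)cc1`, was tested in an ADME assay on HepG2 cells (Homo sapiens) for cytotoxicity, read by sulforhodamine B assay, with a stated time of 48 h; on this read-out lower numbers stand for higher toxicity in this test and higher numbers for lower toxicity in this test. In this assay compound 2 gives > 220000 nM, which is a limit of the assay rather than a measured number. Going by the values given here, its only measured neighbour is compound 1, `COc1nc2ccccc2cc1/C=C/c1noc(-c2ccccc2)n1`. In this assay compound 1 gives > 240000 nM, again a limit and not a number. Among the compounds with values here, the one step between measured compounds, a step that the two limits leave unreadable from compound 1 to compound 2, therefore cannot be read, because the limit of > 220000 nM in this assay, at which 1 of the 2 values shown sits, and the limit of > 240000 nM in this assay, at which 1 of the 2 values shown sits, both mark where the assay stops reporting. Compound 3, `COc1nc2ccccc2cc1/C=C/c1noc(-c2ccc(Br)cc2)n1`, has not yet been measured. It differs from compound 2 by bromo in place of methoxy on an aromatic carbon. No measured step bears on this change with a readable size, and nothing shown points to a step beyond the scatter in either direction. For compound 3 the expected step that the limit leaves unreadable from compound 2 to compound 3 is essentially none. Compound 3 is accordingly estimated to give 250000 nM in this assay, within 100000 nM to 600000 nM, most likely again reported only as a limit.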

Compound 3, half-maximal cytotoxic concentration: > 195000 nM
Compound 3 gave a limit, no number; the forecaster's own chance of this, stated with the estimate: 80%; the middle value is on the limit's open side.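

In this assay compound 3 again gives only a limit, like compound 1 and compound 2, so neither step to compound 3 can be read. The compounds shown leave open whether hydrogen, methoxy or bromo at this place makes any difference to toxicity in this assay.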